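The source may hold more compounds than are shown below. What is called first, only, known or untested is meant among the compounds shown, and "the series" means these compounds.

Measured compounds in an assay on isolated protein for inhibition of Tryptophan 2,3-dioxygenase (Homo sapiens), read by fluorescence and mass spectrometry, with stated times of 5 min and 15 min; on this read-out lower numbers stand for stronger inhibition and higher numbers for weaker inhibition: compound 1 `Nc1oncc1-c1ccccc1`, 140 nM; compound 2 `Cc1noc(N)c1-c1ccccc1`, 25000 nM; compound 3 `Nc1oncc1-c1ccc(Cl)cc1`, 830 nM.

Compound 3 stands second highest of the three numbers, nearest to compound 1 and furthest from compound 2. Compound 4 `Nc1oncc1-c1ccc(F)cc1` differs from compound 3 by fluoro in place of chloro on an aromatic carbon. The step that bears on this place is a 5.9-fold higher number from compound 1 to compound 3 (0.77 log units; beyond the scatter), a modest rise; the step of a 180-fold higher number from compound 1 to compound 2 (2.25 log units; beyond the scatter) concerns another position and only shows how steeply this series can move. Replacing chloro by fluoro at the same position is expected to take compound 4 back toward the number of compound 1, a modest step down in this assay, expected as a 2.8-fold lower number from compound 3 to compound 4 (0.44 log units; beyond the scatter). Compound 4 is therefore estimated at 300 nM, with a range of 100 nM to 1000 nM.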

Compound 4, half-maximal inhibitory concentration: 580 nM
Beside the measured number, compound 4's estimate is 1.9-fold (0.29 log units) below it; the measured number falls inside the stated range.
By their numbers in this assay, from the lowest: compound 1; then compounds 4 and 3 (each within the scatter of the next); then compound 2.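

In this assay, fluoro and chloro on this aromatic carbon, para to a group of 6 heavy atoms, are not separated (a 1.4-fold lower number from compound 3 to compound 4 (0.16 log units; within the scatter)). Fluoro in place of hydrogen still gives a modest rise (a 4.1-fold higher number from compound 1 to compound 4 (0.62 log units; beyond the scatter)), so at this position both halogens, in compound 3 and compound 4, read weaker than hydrogen in compound 1. No evidence available explains this result.

Open, as far as these compounds go, is whether a group other than a halogen here, such as an amine, a nitrile or methoxy, would match compound 1, and whether fluoro behaves the same elsewhere on the six-membered ring.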